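The compounds below may be only part of what the source reports. "The series", "measured", "known", "first", "only" and "open" are said of these compounds alone.

Compound 1 `Nc1ncnc2c1c(-c1cnc3[nH]ccc3c1)nn2CCCCCCCCCC(=O)NO` gives 98.3% in an assay on isolated protein for inhibition of protein deacetylase HDAC6 (Homo sapiens), with a stated time of 15 min, tested at 1 uM; on this read-out lower numbers stand for less inhibition and higher numbers for more inhibition at the one concentration tested (going by the name of the read-out).
Compound 2 `Nc1ncnc2c1c(-c1cnc3[nH]ccc3c1)nn2CCCCCCC(=O)NO` gives 99.1% in this assay.
Compound 3 `Nc1nc2cc(-c3nn(CCCCCC(=O)NO)c4ncnc(N)c34)ccc2o1` gives 97.8% in this assay.

All three measured compounds carry a hydroxamic acid at the end of a flexible chain on a shared aromatic core, and all three sit near the top of what this assay can report. Compound 2 and compound 1 differ in one place: 3-(hydroxycarbamoyl)propyl in place of hydroxycarbamoyl on a saturated chain carbon, six bonds along the chain from an aromatic nitrogen. The step of a number 0.8 percentage points lower from compound 2 to compound 1 (within the scatter) is within the scatter, so lengthening the chain here left the read-out essentially unchanged.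

Compound 3 carries a different core; the difference between the two cores is not broken down here. Compound 4 `Nc1nc2cc(-c3nn(CCCCCCCCC(=O)NO)c4ncnc(N)c34)ccc2o1` is made from compound 3 by 3-(hydroxycarbamoyl)propyl in place of hydroxycarbamoyl on a saturated chain carbon, five bonds along the chain from an aromatic nitrogen. This is the same kind of change as that from compound 2 to compound 1, though the place differs: here it sits five bonds along the chain from an aromatic nitrogen rather than six.

Because compound 3 already gives 97.8%, and because a number 0.8 percentage points lower from compound 2 to compound 1 (within the scatter) was within the scatter, the step of a number 0.3 percentage points lower from compound 3 to compound 4 (within the scatter) is expected to be small. Compound 4 is therefore estimated at 97.5%, likely between 93% and 99.5%.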

Compound 4, a percentage reported as inhibition, at one concentration (the size of the read-out at that concentration, not a potency): 99%
Compound 4: the middle estimate sits 1.5 percentage points below what was measured; the measured number falls inside the stated range.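

Putting 3-(hydroxycarbamoyl)propyl in place of hydroxycarbamoyl on the core of compound 3 gives a step in this assay of a number 1.2 percentage points higher from compound 3 to compound 4 (within the scatter). Set beside the earlier step, the change reads the same on both cores: the same change on two cores in this assay, a number 0.8 percentage points lower (within the scatter) from compound 2 to compound 1 and a number 1.2 percentage points higher (within the scatter) from compound 3 to compound 4, 2 percentage points apart, within the scatter of two such steps

This shows that the number stays level with the longer chain on both cores at the one concentration tested, but all four compounds sit near the top of what this read-out can report, so it does not show that the change would carry over equally among compounds with lower numbers, and it gives no measure of potency.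

The compounds shown leave open how a much shorter chain would read on either core, or an end group other than the hydroxamic acid, such as a carboxylic acid or an amine. They also leave open whether these chain lengths would separate at a lower concentration, where the read-out would have room to move.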